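A Benzyl Group Enters on the Ring Nitrogen of Compound 3

A few compounds are considered here, and "the series" means these few. Any claim that something is new, unique, unknown or untested is made for them only; others in the source may bear on it.

Of the compounds shown here, three have been measured so far in an assay on cells for inhibition of Polyunsaturated fatty acid 5-lipoxygenase (Rattus norvegicus), tested at 5 uM; on this read-out lower numbers stand for less inhibition and higher numbers for more inhibition at the one concentration tested (going by the name of the read-out). Compound 1, `O=C(CCc1cn(C(=O)c2ccccc2)c2ccccc12)N1CCOCC1`, gives 23.4% in this assay. Compound 2, `COc1ccc2c(c1)c(CCCC(=O)N1CCOCC1)c(C)n2Cc1ccccc1`, gives 54.2%. Compound 3, `CC(C)(C)OC(=O)N1CCN(C(=O)CCCc2c[nH]c3ccccc23)CC1`, gives 84.1% and stands highest of the three numbers: compound 2 lies closest to it, yet the gap between them is beyond the usual scatter, and compound 1 lies furthest away, also beyond the scatter. No pair among these three differs in only one place, so the gaps between them cannot be tied to a single structural change.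

Compound 4, `CC(C)(C)OC(=O)N1CCN(C(=O)CCCc2cn(Cc3ccccc3)c3ccccc23)CC1`, has not yet been measured. It differs from compound 3 in one place: benzyl in place of hydrogen on an aromatic nitrogen. For the measured compounds named here, since no single-change step has been measured here, the direction must be judged from the compounds as they stand. Compound 2 also carries a benzyl on such a ring nitrogen and sits well below compound 3, but it differs from compound 3 in other places too, so that comparison is only a hint.

The expected step from compound 3 to compound 4 is a moderate fall, a number 19.1 percentage points lower from compound 3 to compound 4 (beyond the scatter), beyond the scatter. Compound 4 is therefore estimated at 65%, with a likely range from 40% to 85%.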

Compound 4, a percentage reported as inhibition, at one concentration (the size of the read-out at that concentration, not a potency): 38.2%
Estimate against measurement, compound 4: 26.8 percentage points above; measured number below the stated range.
By their numbers in this assay, from the lowest: compound 1; then compound 4; then compound 2; then compound 3.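

In this assay, for the compounds shown here, this is the first step that alters one place and leaves the rest of the molecule untouched: benzyl in place of hydrogen on the aromatic nitrogen gives a number 45.9 percentage points lower from compound 3 to compound 4 (beyond the scatter), a large step. This shows that the read-out responds strongly to what sits on this ring nitrogen, at least with the rest of the structure held as it is in compound 3. Going by these compounds alone, the earlier compounds could only hint at this, since they differ from one another in more than one place, and nothing measured so far explains why the number falls here.

This single step removes the hydrogen and adds the benzyl at the same time, so it cannot tell whether losing the hydrogen or gaining the benzyl matters more; an ethyl group on the same nitrogen would be one way to separate the two. It also leaves open whether the fall holds for other groups at this position, such as a chain ending in a carboxylic acid or an amine, or for a benzyl carrying a fluorine on its ring.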